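From 2-chlorophenyl to 4-methoxyphenyl on a shared core

The source may report more compounds than this note shows. Statements on the series, on what has been measured and on what is new or still open speak of the compounds shown alone.

Measured in a functional assay on HepG2 cells (Homo sapiens) for inhibition, read by MTT assay, with a stated time of 72 h; a higher number here means a weaker inhibitor, a lower number a stronger inhibitor:
- Compound 1 `CC(C)(C)n1cc2c(n1)C(=O)CC1(CCN(C(=O)c3cc(-c4ccc(Cl)cc4)nc4ccccc34)CC1)O2` gives 630 nM
- Compound 2 `CC(C)(C)n1cc2c(n1)C(=O)CC1(CCN(C(=O)c3cc(-c4ccccc4Cl)nc4ccccc34)CC1)O2` gives > 10000 nM (a limit)

The reading for compound 2, > 10000 nM, is a limit and not a number. Compound 3 `COc1ccc(-c2cc(C(=O)N3CCC4(CC3)CC(=O)c3nn(C(C)(C)C)cc3O4)c3ccccc3n2)cc1` keeps the shared core and carries 4-methoxyphenyl in place of 2-chlorophenyl on an aromatic carbon. For the measured compounds named here, one measured step bears on this change: an at least 15-fold higher number from compound 1 to compound 2 (1.20 log units; beyond the scatter). That large step came with 2-chlorophenyl in place of 4-chlorophenyl. Compound 1, with its 4-chlorophenyl group and a value of 630 nM, is therefore the closer guide. A large step toward a lower number is expected in this assay. Going by the values given here, no measured compound carries 4-methoxyphenyl, so the range is wide. The estimated change is an at least 6.6-fold lower number from compound 2 to compound 3 (0.82 log units; beyond the scatter). For compound 3 the expected value is 1500 nM, with an estimated range of 300 nM to 8000 nM.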

Compound 3, half-maximal inhibitory concentration: 2780 nM
Beside the measured number, compound 3's estimate is 1.9-fold (0.27 log units) below it; the measured number falls inside the stated range.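

In this assay, 4-methoxyphenyl on this aromatic carbon gives a measurable value where 2-chlorophenyl did not, with an at least 3.5-fold lower number from compound 2 to compound 3 (0.55 log units; beyond the scatter). Compound 2 gives only a limit and not a number, which leaves the true size of that step unknown: the limit of > 10000 nM in this assay, at which 1 of the 3 values shown sits. The choice of group still matters among those named with a 4, since 4-methoxyphenyl does worse than 4-chlorophenyl, with a 4.4-fold higher number from compound 1 to compound 3 (0.64 log units; beyond the scatter).

Compound 3 differs from compound 2 in both the group's attachment pattern and its substituent, so the two contributions cannot be separated, and 2-methoxyphenyl would be the compound to tell them apart. As far as these compounds go, how plain phenyl, 4-fluorophenyl or 4-aminophenyl would read at this carbon also stays open.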